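One Flipped Stereocentre in a Growth Inhibitor

The source may report more compounds than this note shows. Statements on the series, on what has been measured and on what is new or still open speak of the compounds shown alone.

Compound 1 (`Cc1cn([C@H]2C[C@H](CC3=CC(=O)C(=O)C=C3)[C@@H](CO[Si](C)(C)C(C)(C)C)O2)c(=O)[nH]c1=O`), result (no result reported)
Compound 2 (`COc1ccc(C2([C@H]3C[C@H](n4cc(C)c(=O)[nH]c4=O)O[C@@H]3CO[Si](C)(C)C(C)(C)C)SCCCS2)cc1OC`), measured at (3310 nM)

Among the compounds with values here, in a functional assay on MKN-28 cells (Homo sapiens) for inhibition, read by sulforhodamine B assay, with a stated time of 48 h (on this read-out lower numbers stand for stronger inhibition of growth and higher numbers for weaker inhibition of growth), compound 2 gives 3310 nM as the only number so far, so it cannot yet be ranked against another compound. Compound 3 (`COc1ccc(C2([C@H]3C[C@@H](n4cc(C)c(=O)[nH]c4=O)O[C@@H]3CO[Si](C)(C)C(C)(C)C)SCCCS2)cc1OC`) differs from it in a single way (the two compounds have the same atoms and bonds and differ only in configuration as drawn: 1 of 3 stereo elements differ; a stereocentre at a saturated ring carbon is drawn R in compound 2 and S in compound 3). Within the data shown here, no measured pair shows what such a change does, so no direction can be argued, and no step beyond the usual scatter is expected. The expected step is small (a 1.0-fold lower number from compound 2 to compound 3 (0.00 log units; within the scatter)). Compound 3 is expected at 3300 nM within an estimated range from 1200 nM to 9000 nM for now.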

Compound 3, concentration for 50% growth inhibition: 4900 nM
Estimate against measurement, compound 3: 1.5-fold (0.17 log units) below, within the range that was stated.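

In this assay, within the data shown here, inverting this one saturated ring carbon gives a 1.5-fold higher number from compound 2 to compound 3 (0.17 log units; within the scatter), the first measured pair at this stereocentre. Only one thing separates the two compounds: the fact that compounds 2 and 3 differ only in the configuration as drawn At this position, the two drawn configurations cannot be told apart on this read-out.

Going by these compounds, whether this stereocentre matters as little in other members remains open, for example where an amine or a carboxylic acid is attached to the shared core. Among these compounds, compound 1 has no number, so no step to it can be read.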